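The source may hold more compounds than are shown below. What is called first, only, known or untested is meant among the compounds shown, and "the series" means these compounds.

Compound 1 (`O=C1c2ccc(O)c(O)c2C(=O)N1Cc1ccccc1`) offers no number to start from: in an ADME assay on HOS cells (Homo sapiens) for cytotoxicity (on this read-out lower numbers stand for stronger inhibition and higher numbers for weaker inhibition), compound 1 stands as "not determined" (no result reported) and gives no single reference point. The step to compound 3 (`O=C1c2ccc(O)c(O)c2C(=O)N1Cc1cccc(Br)c1`) turns phenyl into 3-bromophenyl, with bromo in place of hydrogen on an aromatic carbon. The nearest measured number comes from compound 2 (`O=C1c2c(ccc(O)c2O)CN1Cc1cccc(Br)c1`), which also bears the 3-bromophenyl group. In this assay, going by the values given here, compound 2 gives 7240 nM as a lone value, and it shows no step. Among the compounds with values here, with no measured step to lean on, only a modest move toward lower numbers, meaning somewhat stronger inhibition, is expected in this assay on going from compound 1 to compound 3, and that move may stay within the usual scatter. In this assay the estimated value for compound 3 is 9000 nM with 3000 nM to 35000 nM as the expected range.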

Compound 3, half-maximal inhibitory concentration: 11400 nM
Estimate against measurement, compound 3: 1.3-fold (0.10 log units) below; the range from low to high includes it.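

In this assay, going by these compounds alone, compound 1 stands as "not determined" (no result reported), so no step from it to compound 3 can be read. The compounds shown leave open what bromo in place of hydrogen does on this read-out. No measurement here offers an explanation for the value of compound 3.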